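The compounds below may be only part of what the source reports. "The series", "measured", "known", "first", "only" and "open" are said of these compounds alone.

Compound 1 `C[Si](C)(C)C#Cc1cc(-c2nc3cc(F)ccc3s2)ccc1N` gives 210 nM in a functional assay on MDA-MB-468 cells (Homo sapiens) for inhibition, with a stated time of 72 h; a higher number here means a weaker inhibitor of growth, a lower number a stronger inhibitor of growth. Compound 2 `N#Cc1cc(-c2nc3c(F)cccc3s2)ccc1N` gives 80 nM in this assay. Compound 3 `C#Cc1cc(-c2nc3c(F)cccc3s2)ccc1N` gives 30 nM in this assay.

Compound 3 stands lowest of the three; its nearest neighbour is compound 2, the step of a 2.7-fold lower number from compound 2 to compound 3 (0.43 log units; beyond the scatter) lying beyond the scatter, and compound 1 is furthest. Compound 4 `C[Si](C)(C)C#Cc1cc(-c2nc3c(F)cccc3s2)ccc1N` differs from compound 3 by a group of 4 heavy atoms (3 carbon, 1 silicon; no ring) in place of a hydrogen atom, on a triple-bonded carbon. For the measured compounds named here, no measured step matches this change directly. Going by the values given here, compound 1 carries the same silicon-bearing group on a different core, and its value is higher than that of compound 3, while the only measured step, a 2.7-fold lower number from compound 2 to compound 3 (0.43 log units; beyond the scatter), concerns the cyano-to-ethynyl exchange and is modest. An upward step is therefore expected, estimated at a 3.3-fold higher number from compound 3 to compound 4 (0.52 log units; beyond the scatter). The estimate for compound 4 is 100 nM, ranging from 35 nM to 300 nM.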

Compound 4, concentration for 50% growth inhibition: 230 nM
For compound 4 the middle estimate is 2.3-fold (0.36 log units) below the measured one, and the stated range covers the measured number.
By their numbers in this assay, from the lowest: compound 3; then compound 2; then compounds 1 and 4 (each within the scatter of the next).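

In this assay the silicon-bearing group on the triple-bonded carbon gives a 7.7-fold higher number from compound 3 to compound 4 (0.88 log units; beyond the scatter) on an unchanged core, so replacing this hydrogen atom is not tolerated without loss. Set against the nitrile, the same group gives a 2.9-fold higher number from compound 2 to compound 4 (0.46 log units; beyond the scatter) and so reverses the order seen with ethynyl, which gives a lower number than the nitrile at this aromatic carbon. No measurement here explains the loss. Open, as far as these compounds go, is whether a smaller group on the triple-bonded carbon, such as methyl, or a longer chain ending in an amine, would keep the number of compound 3.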